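Amino in place of chloro: expectation for compound 4

The source may hold more compounds than are shown below. What is called first, only, known or untested is meant among the compounds shown, and "the series" means these compounds.

In an ADME assay on BEAS-2B cells (Homo sapiens) for cytotoxicity, read by CCK-8 assay, with a stated time of 48 h (a higher number here means a weaker inhibitor, a lower number a stronger inhibitor), compound 3 (`C=CC(=O)Nc1cccc(Oc2nc(Nc3ccc(N4CCN(C)CC4)c(Cl)c3)nc3[nH]ccc23)c1`) gives 3800 nM. Compound 1 (`C=CC(=O)Nc1cccc(Oc2nc(Nc3ccc(N4CCN(C)CC4)c([N+](=O)[O-])c3)nc3[nH]ccc23)c1`) gives 3680 nM, within the scatter of that number, while compound 2 (`C=CC(=O)Nc1cccc(Oc2nc(Nc3ccc(N4CCN(C)CC4)c(N)c3)nc3c2ccn3COC(=O)C(C)(C)C)c1`) stands higher at 9540 nM. Compound 4 (`C=CC(=O)Nc1cccc(Oc2nc(Nc3ccc(N4CCN(C)CC4)c(N)c3)nc3[nH]ccc23)c1`) remains unmeasured. It carries amino in place of chloro on an aromatic carbon, ortho to a 4-methylpiperazin-1-yl group: amino in place of chloro on an aromatic carbon. For the measured compounds named here, one measured step bears on this place: a 1.0-fold higher number from compound 1 to compound 3 (0.01 log units; within the scatter), chloro in place of nitro, which lies within the scatter. Going by the values given here, no measured step shows amino entering on an otherwise unchanged structure. The expected change in this assay is therefore small, none beyond the scatter: a 1.2-fold higher number from compound 3 to compound 4 (0.07 log units; within the scatter). The estimate for compound 4 is 4500 nM, with an expected range from 2000 nM to 10000 nM.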

Compound 4, half-maximal inhibitory concentration: 7800 nM
Compound 4: the middle estimate sits 1.7-fold (0.24 log units) below what was measured, within the range that was stated.
By their numbers in this assay, from the lowest: compounds 1 and 3 (each within the scatter of the next); then compounds 4 and 2 (each within the scatter of the next).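

In this assay this aromatic carbon no longer looks indifferent to its substituent: chloro and nitro could not be separated, but amino gives a 2.1-fold higher number from compound 3 to compound 4 (0.31 log units; beyond the scatter) and a 2.1-fold higher number from compound 1 to compound 4 (0.33 log units; beyond the scatter). Both steps are modest. Replacing (((tert-butyl)carbonyl)oxy)methyl on the aromatic nitrogen with hydrogen, with amino in place, gives only a 1.2-fold lower number from compound 2 to compound 4 (0.09 log units; within the scatter). Nothing available accounts for the shift with amino. Open, as far as these compounds go, is whether a methylamino, dimethylamino or acetamido group on this carbon would track amino or stay with chloro and nitro.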